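The compounds below may be only part of what the source reports. "The series", "measured", "known", "first", "only" and "open" are said of these compounds alone.

Of the compounds shown here, three sharing one core have been tested in a functional assay on CHO cells with adenosine receptor A1 (Homo sapiens) as the target, read by cAMP accumulation and immunoassay, with a stated time of 6 min, tested at 0.1 uM; a higher number here means a weaker effect of the compound at the concentration tested, a lower number a stronger effect. Compound 1 `Nc1scc(CN2CCN(c3ccc([N+](=O)[O-])cc3)CC2)c1C(=O)c1ccc(Cl)cc1` gives -13%. Compound 2 `Nc1scc(CN2CCN(c3cccnc3)CC2)c1C(=O)c1ccc(Cl)cc1` gives 3.4%, and compound 3 `Nc1scc(CN2CCN(c3ccccc3F)CC2)c1C(=O)c1ccc(Cl)cc1` gives -1%. Compound 3 stands second highest of the three numbers: its nearest neighbour is compound 2, a gap within the scatter, while compound 1 is furthest, a gap beyond the scatter. The steps measured so far all exchange the aromatic group on the amine nitrogen in the ring: a number 16.4 percentage points higher from compound 1 to compound 2 (beyond the scatter) and a number 12 percentage points higher from compound 1 to compound 3 (beyond the scatter) were modest, while a number 4.4 percentage points lower from compound 2 to compound 3 (within the scatter) fell within the scatter.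

Compound 4 `Nc1scc(CN2CCN(c3cc(F)ccc3F)CC2)c1C(=O)c1ccc(Cl)cc1` differs from compound 3 by fluoro in place of hydrogen on an aromatic carbon. Going by the values given here, no measured step adds a fluoro on this ring, so the nearest guide is the small spread among the aryl variants, and in particular the step from compound 2 to compound 3. A step of a number 1 percentage points higher from compound 3 to compound 4 (within the scatter) in this assay is therefore expected, none beyond the scatter. Compound 4 is estimated at 0%, within -12% to 12%.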

Compound 4, a percentage reported as activity, at one concentration (the size of the read-out at that concentration, not a potency): -13%
Beside the measured number, compound 4's estimate is 13 percentage points above it; measured number below the stated range.
By their numbers in this assay, from the lowest: compounds 1 and 4 (each within the scatter of the next); then compounds 3 and 2 (each within the scatter of the next).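

In this assay, one fluoro on an aromatic carbon, meta to a large group and para to a fluoro group, gives a number 12 percentage points lower from compound 3 to compound 4 (beyond the scatter), so a change of a single heavy atom on this ring moves the number beyond the scatter. The resulting 2,5-difluorophenyl group also separates from the pyridin-3-yl group, with a number 16.4 percentage points lower from compound 2 to compound 4 (beyond the scatter), whereas the comparison with the 4-nitrophenyl group shows no change at the digits printed from compound 1 to compound 4 (within the scatter), so two different aryl groups on the ring nitrogen share one number. No evidence at hand accounts for the shift at this position.

The compounds shown leave open whether a chloro, a methyl or a methoxy on the same aromatic carbon would move the number as the fluoro does. They also leave open whether this fluoro would have the same effect without the fluoro already present in compound 3.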